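This account rests on a few compounds, and the source may have more. Where it says the series, first, only, none or still open, it means among the compounds named here.

Measured so far:
Compound 1 `COc1ccc(-c2ccc(-c3ccc(C(=N)N)cc3)s2)cc1` gives 924 nM.
Compound 2 `N=C(N)c1ccc(-c2ccc(-c3cc(Cl)cc(Cl)c3)s2)cc1` gives 1520 nM.

Both numbers come from a functional assay on MDA-MB-435 cells (Homo sapiens) for inhibition, read by sulforhodamine B assay, with a stated time of 48 h; on this read-out higher numbers stand for weaker inhibition of growth and lower numbers for stronger inhibition of growth. Compound 1 has the lower of the two numbers, but its gap to compound 2 lies within the usual scatter, so the two cannot be told apart. Compound 3 `N=C(N)c1ccc(-c2ccc(-c3ccc(F)cc3)s2)cc1` is not yet measured. It differs from compound 1 by fluoro in place of methoxy on an aromatic carbon. Among the compounds with values here, no step between measured compounds that differ in one place is available, so nothing measured here tells how this change acts. The step from compound 1 to compound 3 is expected to stay within the scatter, a 1.3-fold higher number from compound 1 to compound 3 (0.11 log units; within the scatter). Compound 3 is estimated at 1200 nM, in the range 500 nM to 3000 nM.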

Compound 3, concentration for 50% growth inhibition: 1660 nM
The estimate for compound 3 lay 1.4-fold (0.14 log units) below the measured number; measured number inside the range.
By their numbers in this assay, from the lowest: compounds 1, 2 and 3 (each within the scatter of the next).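

In this assay, within the data shown here, fluoro in place of methoxy on an aromatic carbon, para to a large group, gives a 1.8-fold higher number from compound 1 to compound 3 (0.25 log units; within the scatter) and so offers the first direct reading of a change at this position: the two compounds cannot be told apart. Losing the methoxy oxygen and carbon for a single fluorine therefore leaves no measurable mark on this read-out. No available evidence bears on this result. Going by these compounds, whether an amine, a hydroxyl or a carboxylic acid at this position would shift the number beyond the scatter remains open.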